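A shorter chain on a shared core: no change expected

The compounds below may be only part of what the source reports. "The series", "measured", "known", "first", "only" and "open" are said of these compounds alone.

Measured so far:
Compound 1 `Nc1ncnc2c1nc(NCCCCCCCCNC(=O)CI)n2[C@@H]1O[C@H](COP(=O)(O)OP(=O)(O)OP(=O)(O)O)[C@@H](O)[C@H]1O` gives 0%.
Compound 2 `Nc1ncnc2c1nc(NCCCCNC(=O)CI)n2[C@@H]1O[C@H](COP(=O)(O)OP(=O)(O)OP(=O)(O)O)[C@@H](O)[C@H]1O` gives 0%.
Compound 3 `Nc1ncnc2c1nc(NCCCCCCNC(=O)CI)n2[C@@H]1O[C@H](COP(=O)(O)OP(=O)(O)OP(=O)(O)O)[C@@H](O)[C@H]1O` gives 0%.

All three were tested in an assay on isolated protein for inhibition of hexokinase-3 (Rattus norvegicus), with a stated time of 6 h, tested at 10 mM; a lower number here means less inhibition, a higher number more inhibition at the concentration tested (going by the name of the read-out). Compound 3 stands level with compounds 1 and 2 at the digits printed: the step of no change at the digits printed from compound 1 to compound 3 (within the scatter) shows no change, and the step of no change at the digits printed from compound 2 to compound 3 (within the scatter) likewise shows none. The third pair, no change at the digits printed from compound 1 to compound 2 (within the scatter), also lies within the scatter. So shortening the chain that carries the iodomethyl carbonyl amino group has so far left the read-out unchanged.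

Compound 4 `Nc1ncnc2c1nc(NCCNC(=O)CI)n2[C@@H]1O[C@H](COP(=O)(O)OP(=O)(O)OP(=O)(O)O)[C@@H](O)[C@H]1O` carries this one step further. The change from compound 3 is ((iodomethyl)carbonyl)amino in place of 4-(((iodomethyl)carbonyl)amino)butyl on a saturated chain carbon, two bonds along the chain from a nitrogen on an aromatic ring.

The three measured steps all concern the same chain, shortened by different amounts, and none of them moved the read-out beyond the scatter. The step to compound 4 is of the same kind, so the expected step of no change at the digits printed from compound 3 to compound 4 (within the scatter) is none beyond the scatter. Compound 4 is therefore estimated at 0%, with a range from 0% to 10%.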

Compound 4, a percentage reported as inhibition, at one concentration (the size of the read-out at that concentration, not a potency): 0%
Compound 4: the middle estimate sits on the measured number at the digits printed; the range from low to high includes it.
By their numbers in this assay, from the lowest: compounds 1, 2, 3 and 4 (each within the scatter of the next).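

In this assay, the read-out stays flat even for the shortest chain shown, where ((iodomethyl)carbonyl)amino replaces the longer groups on a saturated chain carbon, two bonds along the chain from a nitrogen on an aromatic ring: no change at the digits printed from compound 3 to compound 4 (within the scatter), no change at the digits printed from compound 2 to compound 4 (within the scatter) and no change at the digits printed from compound 1 to compound 4 (within the scatter). The same shortening also reads alike when it starts from different chain lengths: the same change on two cores in this assay, no change at the digits printed (within the scatter) from compound 1 to compound 2 and no change at the digits printed (within the scatter) from compound 3 to compound 4, 0 percentage points apart, within the scatter of two such steps A second such pair agrees: the same change on two cores in this assay, no change at the digits printed (within the scatter) from compound 1 to compound 3 and no change at the digits printed (within the scatter) from compound 2 to compound 4, 0 percentage points apart, within the scatter of two such steps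

With compound 4 at 0% and the other three level with it, no chain length here gives a reading that can be ranked against another. As far as these compounds go, whether a chain end bearing a free amine or a chloroacetamide in place of the iodoacetamide would give any inhibition remains open.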